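Piperazine nitrogen substituent and tolerated concentration

This account rests on a few compounds, and the source may have more. Where it says the series, first, only, none or still open, it means among the compounds named here.

compound 1 `CN1CCN(CC(=O)Nc2ccc(-c3nc4cc(C(F)(F)F)ccc4n3C)cc2)CC1` — 44000 nM
compound 2 `Fc1cccc(F)c1-c1nc2cc(Cl)c(Cl)cc2[nH]1` — 43000 nM

In an ADME assay on MDBK cells (Bos taurus) for cytotoxicity, read by MTT assay, with a stated time of 96 h (a higher number here means that more compound is tolerated, a lower number that less compound is tolerated), compound 1 gives 44000 nM. Compound 2 gives 43000 nM in this assay, and the two values lie within the usual scatter of each other, so compound 1 does not stand apart from compound 2. Compound 3 `Cn1c(-c2ccc(NC(=O)CN3CCN(c4ccccc4)CC3)cc2)nc2cc(C(F)(F)F)ccc21` has not been measured. It differs from compound 1 in one place: phenyl in place of methyl on an amine nitrogen in a ring. Within the data shown here, no measured pair shows this change, so its effect on tolerated concentration is open. The step of a 2.2-fold lower number from compound 1 to compound 3 (0.34 log units; beyond the scatter) is expected to be modest, toward a lower number. For compound 3 the estimate in this assay is 20000 nM, with a range from 7000 nM to 50000 nM.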

Compound 3, half-maximal cytotoxic concentration: 1400 nM
Compound 3: middle estimate off by 14-fold (1.15 log units), on the high side; measured number below the stated range.
By their numbers in this assay, from the lowest: compound 3; then compounds 2 and 1 (each within the scatter of the next).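

Going from 4-methylpiperazin-1-yl to 4-phenylpiperazin-1-yl gives, in this assay, a 31-fold lower number from compound 1 to compound 3 (1.50 log units; beyond the scatter). The tolerated concentration at this amine nitrogen therefore responds strongly to the substituent, which compounds 1 and 2 alone could not show, as they do not differ in one place. Nothing available explains the step. Open, from the compounds shown here alone, is whether the drop follows the aromatic ring or simply the larger substituent. A cyclohexyl group on this nitrogen would separate the two, and a hydrogen or a benzyl group would show how the tolerated concentration runs on either side of phenyl.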